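Chain extension on the aryl ether oxygen of the shared core

The source may report more compounds than this note shows. Statements on the series, on what has been measured and on what is new or still open speak of the compounds shown alone.

Measured in a functional assay, read by spectrophotometry, with a stated time of 6 min; a higher number here means a weaker inhibitor, a lower number a stronger inhibitor:
compound 1, `COc1cc(O)c(C(C)=O)cc1Br`: 31400000 nM
compound 2, `CCOc1cc(OC)c(Br)cc1C(C)=O`: 36000000 nM
compound 3, `CCCCCCOc1cc(OC)c(Br)cc1C(C)=O`: 35700000 nM

All three numbers sit close together. Compound 3 stands second highest of the three, with compound 2 nearest and compound 1 furthest, and neither gap reaches beyond the scatter: a 1.1-fold higher number from compound 1 to compound 3 (0.06 log units; within the scatter) and a 1.0-fold lower number from compound 2 to compound 3 (0.00 log units; within the scatter). The remaining step, a 1.1-fold higher number from compound 1 to compound 2 (0.06 log units; within the scatter), is likewise within the scatter. Nothing in this set moves the read-out.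

Compound 4, `CCCCCCCCCCCCOc1cc(OC)c(Br)cc1C(C)=O`, carries the change (hexyl in place of hydrogen on a saturated chain carbon, six bonds along the chain from an oxygen on an aromatic ring).

The step that bears most directly on it is a 1.0-fold lower number from compound 2 to compound 3 (0.00 log units; within the scatter), a lengthening of the same chain at a saturated chain carbon, which left the number flat. The two ether steps from compound 1, a 1.1-fold higher number from compound 1 to compound 2 (0.06 log units; within the scatter) and a 1.1-fold higher number from compound 1 to compound 3 (0.06 log units; within the scatter), point the same way. A further lengthening of this chain is therefore expected to give a 1.0-fold higher number from compound 3 to compound 4 (0.00 log units; within the scatter), with no movement beyond the scatter in either direction. Compound 4 is estimated at 36000000 nM, with a range from 15000000 nM to 85000000 nM.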

Compound 4, half-maximal inhibitory concentration: 32700000 nM
Beside the measured number, compound 4's estimate is 1.1-fold (0.04 log units) above it, and the stated range covers the measured number.
By their numbers in this assay, from the lowest: compounds 1, 4, 3 and 2 (each within the scatter of the next).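

In this assay, adding hexyl six bonds along the chain from the oxygen on the aromatic ring gives a 1.1-fold lower number from compound 3 to compound 4 (0.04 log units; within the scatter). The insensitivity seen at the shorter chains therefore extends to compound 4: the numbers of compound 2, compound 3 and compound 4 cannot be told apart, and no compound among these goes against that reading. This position tolerates considerable added saturated chain without any detectable response in this read-out, and no measurement on hand accounts for that.

Still open, from the compounds shown here alone, is whether anything other than a plain saturated chain at this oxygen would move the number, for example a chain ending in an amine or a carboxylic acid. Also open, going by these compounds, is whether a phenyl ring in place of the hexyl would do so.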